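This account rests on a few compounds, and the source may have more. Where it says the series, first, only, none or still open, it means among the compounds named here.

Measured so far in a functional assay on A549 cells (Homo sapiens) for inhibition, read by XTT assay, with a stated time of 48 h; on this read-out higher numbers stand for weaker inhibition and lower numbers for stronger inhibition:

Compound 1 `COc1ccc(C(=O)/C(=C/c2ccc([N+](=O)[O-])cc2)CCOC(C)=O)cc1` — the value reported, > 100000 nM, is a limit of the assay rather than a number.
Compound 2 `COc1ccc(C(=O)/C(=C/C2CCCCC2)CN(C)C(=O)c2ccccc2)cc1` — compound 2 gives 69700 nM.
Compound 3 `C=C(C/C(=C\c1ccc(OC(=O)c2ccccc2)cc1)C(=O)c1ccc(OC)cc1)C(=O)c1ccc(OC)cc1` — the value for compound 3, > 100000 nM, is again only a limit of the assay.

Compound 3 therefore stands at the edge of what this assay can report: no number is known for it, only that its inhibition was too weak to be measured, and the limit of > 100000 nM in this assay, at which 2 of the 3 values shown sit, shows that compound 3 is not alone there. Compound 4 `C=C(C/C(=C\c1ccccc1)C(=O)c1ccc(OC)cc1)C(=O)c1ccc(OC)cc1` differs from compound 3 in one place: hydrogen in place of benzoyloxy on an aromatic carbon. Among the measured compounds shown here, no pair of measured compounds shows what such a change does here, so there is no measured step to lean on. Only compound 2, a different structure, gives a number at all, and that number is itself very weak. The expectation is that the step from compound 3 to compound 4 is a number no higher from compound 3 to compound 4 (the limit leaves the size open), that is, no change beyond the usual scatter and a fair chance of another limit. Compound 4 is estimated at 100000 nM, with a range from 30000 nM to 300000 nM.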

Compound 4, half-maximal inhibitory concentration: 22900 nM
Compound 4: middle estimate off by 4.4-fold (0.64 log units), on the high side; measured number below the stated range.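

In this assay, replacing the benzoyloxy group with hydrogen on the aromatic carbon gives an at least 4.3-fold lower number from compound 3 to compound 4 (0.64 log units; beyond the scatter). Among the compounds shown here, this is the first measured step in the set, and it shows that this position, para to a large group, affects the read-out and that the benzoyloxy group is not needed for a measurable value. The true size of the step remains unknown, since compound 3 has only a limit rather than a number, and it shares that limit with another compound: the limit of > 100000 nM in this assay, at which 2 of the 4 values shown sit.

On these data alone, only benzoyloxy and hydrogen can be compared here, so it remains open how a hydroxyl group, a fluorine atom or an amine at the same carbon would behave. One pair also cannot show whether the same replacement would have a similar effect on a different core.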